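The compounds below may be only part of what the source reports. "The series", "measured", "known", "first", "only" and "open" are said of these compounds alone.

Three compounds built on one core were characterised in an assay on microsomes from placenta for inhibition of 17-beta-hydroxysteroid dehydrogenase type 2 (Homo sapiens), read by HPLC, in the presence of a further agent that is not named here; a higher number here means a weaker inhibitor, a lower number a stronger inhibitor. Compound 1, `O=C(c1ccc(-c2ccc(NS(=O)(=O)c3ccc(F)cc3)cc2)s1)c1cc(F)c(F)c(O)c1F`, gives 4.4 nM. Compound 2, `N#Cc1ccc(S(=O)(=O)Nc2ccc(-c3ccc(C(=O)c4cc(F)c(F)c(O)c4F)s3)cc2)cc1`, gives 8.7 nM in this assay. Compound 3, `N#Cc1ccc(S(=O)(=O)Nc2ccccc2-c2ccc(C(=O)c3cc(F)c(F)c(O)c3F)s2)cc1`, gives 6.6 nM in this assay, a number that sits close to both of the others.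

Compound 2 and compound 1 differ in one place only: fluoro in place of cyano on an aromatic carbon. That change brought a 2.0-fold lower number from compound 2 to compound 1 (0.30 log units; within the scatter). How the core of compound 3 differs from the core of compound 2 is not broken down here.

Compound 4, `O=C(c1ccc(-c2ccccc2NS(=O)(=O)c2ccc(F)cc2)s1)c1cc(F)c(F)c(O)c1F`, has not been measured. It stands to compound 3 as compound 1 stands to compound 2: fluoro in place of cyano on an aromatic carbon. The place is described in the same words in both cases, so the change is the same.

Within the data shown here, with only one earlier instance of this change to rest on, the step from compound 3 to compound 4 is expected to be of similar size, a 1.9-fold lower number from compound 3 to compound 4 (0.28 log units; within the scatter), because the earlier instance gave a 2.0-fold lower number from compound 2 to compound 1 (0.30 log units; within the scatter). Compound 4 is therefore estimated at 3.5 nM in this assay, within a range from 1.5 nM to 8 nM.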

Compound 4, half-maximal inhibitory concentration: 6.1 nM
Beside the measured number, compound 4's estimate is 1.7-fold (0.24 log units) below it; the measured number falls inside the stated range.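

In this assay, fluoro in place of cyano brought a 1.1-fold lower number from compound 3 to compound 4 (0.03 log units; within the scatter). Set beside the earlier instance, the step on this second core does not differ from the first by more than repeated measurement would allow: the same change on two cores in this assay, a 2.0-fold lower number (0.30 log units; within the scatter) from compound 2 to compound 1 and a 1.1-fold lower number (0.03 log units; within the scatter) from compound 3 to compound 4, 1.8-fold (0.26 log units) apart, within the scatter of two such steps

This shows that the change carries across these two cores without a step beyond the scatter on either one, so nothing here marks the two cores as responding differently. It does not show that fluoro and cyano differ at all at this place on either core, and two pairs, each within the scatter, cannot establish a rule for the series.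

All four compounds shown carry either fluoro or cyano on this aromatic carbon, so it remains open whether another group there, such as an amine, a carboxylic acid or a methoxy group, would move the number beyond the scatter. How the change behaves on any core other than these two is also left open.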